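The compounds below may be only part of what the source reports. "The series", "measured", "known", "first", "only" and "open" are said of these compounds alone.

In a physicochemical assay for solubility, in simulated intestinal fluid (on this read-out lower numbers stand for lower solubility and higher numbers for higher solubility), compound 3 `Cc1nc(C)n(CC(=O)N2CCN(c3sc(C(F)(F)F)nc3-c3nc4ccc(C5CCOCC5)cc4[nH]3)C[C@H]2C)n1` gives > 1000 ug/mL and this is a limit of the assay, not a number (see the limit of > 1000 ug/mL in this assay, at which 1 of the 3 values shown sits, for its place among the values shown). Compound 4 `Cc1nc(C)n(CC(=O)N2CCN(c3sc(C(F)(F)F)nc3-c3nc4ccccc4[nH]3)C[C@H]2C)n1` carries hydrogen in place of oxan-4-yl on an aromatic carbon and is otherwise identical to compound 3. Within the data shown here, no measured step covers this change. Compound 1 `Cc1nn(CC(=O)N2CCN(c3sc(C(F)(F)F)nc3-c3nc4ccccc4[nH]3)C[C@H]2C)cc1CN(C)C` gives 645 ug/mL and compound 2 `C[C@@H]1CN(c2sc(C(F)(F)F)nc2-c2nc3ccccc3[nH]2)CCN1C(=O)Cn1cccn1` gives 734 ug/mL with hydrogen on that aromatic carbon as well. Among the measured compounds shown here, the one step between them a 1.1-fold higher number from compound 1 to compound 2 (0.06 log units; within the scatter) lies within the scatter and concerns the side chain. A drop towards these two values is expected in this assay and the estimated step is an at least 1.5-fold lower number from compound 3 to compound 4 (0.18 log units; that floor lies within the scatter) (its true size is hidden by the limit). Compound 4 is estimated at 650 ug/mL (expected range 320 ug/mL to 1000 ug/mL).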

Compound 4, solubility: > 850 ug/mL
Compound 4 was reported as a limit (the forecaster's own chance of this, stated with the estimate: 15%); middle value at least 1.3-fold (0.11 log units) away from the limit.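

In this assay compound 4, with hydrogen on the aromatic carbon, gives > 850 ug/mL, a limit of the assay and not a number. Compound 3 is also a limit, so the step for hydrogen in place of oxan-4-yl cannot be read, yet a limit reading does not depend on oxan-4-yl. With 3,5-dimethyl-1H-1,2,4-triazol-1-yl on the saturated chain carbon, the readable steps are an at least 1.1-fold higher number from compound 2 to compound 4 (0.06 log units; that floor lies within the scatter) and an at least 1.3-fold higher number from compound 1 to compound 4 (0.11 log units; that floor lies within the scatter).

The true values of compound 3 and compound 4 stay hidden. Also open, from the compounds shown here alone, is how a carboxylic acid or a primary amine on that aromatic carbon would read in this assay.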